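A few compounds are considered here, and "the series" means these few. Any claim that something is new, unique, unknown or untested is made for them only; others in the source may bear on it.

In a functional assay on MCF7 cells (Homo sapiens) for inhibition, read by MTT assay, with a stated time of 72 h (on this read-out lower numbers stand for stronger inhibition and higher numbers for weaker inhibition), compound 1 (`COc1cccc(/C=C/C(=O)Nc2cc(OC)c(OC)c(OC)c2)c1`) gives 27000 nM, a far weaker result than compound 2 (`C=C(Br)C(=O)Nc1cccc(/C=C/C(=O)Nc2ccc(OC)c(OC)c2)c1`) at 2800 nM and compound 3 (`C=C(Br)C(=O)Nc1cccc(/C=C/C(=O)Nc2cc(OC)cc(OC)c2)c1`) at 3000 nM. Compound 3 therefore stands level with compound 2, as their numbers lie within the usual scatter of repeated measurements and cannot be told apart. The gap between compound 3 and compound 1 is well beyond that scatter.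

Compound 4 (`C=C(Br)C(=O)Nc1cccc(/C=C/C(=O)Nc2cc(OC)c(OC)c(OC)c2)c1`) has not yet been measured. It differs from compound 3 by a single change, methoxy in place of hydrogen on an aromatic carbon, ortho to two methoxy groups and para to a large group.

Within the data shown here, no measured pair shows this exact change, so its size cannot be read directly from the data. The close agreement of compound 2 at 2800 nM and compound 3 at 3000 nM gives no reason to expect a large shift in this assay, so a modest move towards a lower number seems most likely. The expected step is a 1.7-fold lower number from compound 3 to compound 4 (0.22 log units; within the scatter). For compound 4 the estimated value is 1800 nM, with an expected range of 500 nM to 5000 nM.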

Compound 4, half-maximal inhibitory concentration: 1800 nM
The estimate for compound 4 equals the measured number at the digits printed; low and high end bracket the measured number.
By their numbers in this assay, from the lowest: compounds 4, 2 and 3 (each within the scatter of the next); then compound 1.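

With methoxy on the aromatic carbon ortho to two methoxy groups and para to a large group, this assay shows a 1.7-fold lower number from compound 3 to compound 4 (0.22 log units; within the scatter) and so no change that can be told from repeat-measurement noise. The same kind of change made from the other dimethoxy compound gives a 1.6-fold lower number from compound 2 to compound 4 (0.19 log units; within the scatter) and is also within the scatter, so compound 4 stands level with compound 2 and compound 3. Among these compounds, the one large step is ((1-bromoethenyl)carbonyl)amino in place of methoxy on an aromatic carbon, with a 15-fold lower number from compound 1 to compound 4 (1.18 log units; beyond the scatter) beyond the scatter, and this is the first pair to show that change in a single place. No data here speak to the reason for these steps.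

Going by these compounds, whether an amine, a carboxylic acid or a longer chain such as ethoxy at this carbon would shift the number remains open. Also open, on these data alone, is whether chlorine in place of the bromine would keep the large step.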